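Spirocyclic Sulfonamide in Place of the Pyrazole Sulfone

A few compounds are considered here, and "the series" means these few. Any claim that something is new, unique, unknown or untested is made for them only; others in the source may bear on it.

Compound 1 `CCCn1cc(S(=O)(=O)c2ccc(CNC(=O)N3Cc4ccncc4C3)cc2)cn1` carries a 1-propyl-1H-pyrazol-4-yl group on a sulfonyl sulfur. In an ADME assay on microsomes from liver (Homo sapiens) for pharmacokinetics, read by LC-MS, with a stated time of 60 min, tested at 1 uM (on this read-out higher numbers stand for fast clearance and lower numbers for slow clearance), compound 1 gives 11 mL/min/kg, the highest of the three numbers in hand, although compound 3, the nearest, and compound 2, the furthest, both lie within the scatter of it. Compound 2 `O=C(NCc1ccc(S(=O)(=O)C2CCC(F)(F)CC2)cc1)N1Cc2ccncc2C1` gives 6 mL/min/kg in this assay, and compound 3 `O=C(NCc1ccc(S(=O)(=O)C2CCCOC2)cc1)N1Cc2ccncc2C1` gives 7 mL/min/kg. Each was reached from compound 1 by exchanging the pyrazole for a saturated ring on the sulfonyl sulfur: a 1.8-fold lower number from compound 1 to compound 2 (0.26 log units; within the scatter), and a 1.6-fold lower number from compound 1 to compound 3 (0.20 log units; within the scatter). Between the two of them, a 1.2-fold higher number from compound 2 to compound 3 (0.07 log units; within the scatter).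

Compound 4 `O=C(NCc1ccc(S(=O)(=O)N2CC3(CCOCC3)C2)cc1)N1Cc2ccncc2C1` follows the same route: a group of 9 heavy atoms (7 carbon, 1 nitrogen, 1 oxygen; one four-membered non-aromatic ring with 1 hetero atom, one six-membered non-aromatic ring with 1 hetero atom) in place of a group of 8 heavy atoms (6 carbon, 2 nitrogen; one five-membered aromatic ring with 2 hetero atoms), on a sulfonyl sulfur. The two measured steps that bear on it were each within the scatter, so for compound 4 no step beyond the scatter is expected in this assay. Compound 4 is therefore estimated at 9 mL/min/kg, in a range from 4.5 mL/min/kg to 18 mL/min/kg. That expectation amounts to a 1.2-fold lower number from compound 1 to compound 4 (0.09 log units; within the scatter). Whether the entering group, with its four-membered and six-membered rings, behaves like the earlier saturated replacements is what the measurement will show.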

Compound 4, clearance: 13 mL/min/kg
Compound 4: middle estimate off by 1.4-fold (0.16 log units), on the low side; low and high end bracket the measured number.
By their numbers in this assay, from the lowest: compounds 2, 3, 1 and 4 (each within the scatter of the next, the first and the last beyond it).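

In this assay, among these compounds, only one step at this sulfonyl sulfur lies beyond the scatter, and it is a modest one (a 2.2-fold higher number from compound 2 to compound 4 (0.34 log units; beyond the scatter)). The other two steps stay within the scatter (a 1.2-fold higher number from compound 1 to compound 4 (0.07 log units; within the scatter); a 1.9-fold higher number from compound 3 to compound 4 (0.27 log units; within the scatter)), so compound 4 cannot be told apart from compound 1, which carries the 1-propyl-1H-pyrazol-4-yl group, or from compound 3, which carries the oxan-3-yl group. The saturated replacements therefore no longer read as a single set in this assay: compound 2 and compound 4 stand apart, while compound 3 remains within the scatter of both. Nothing shown here gives a reason for the gap between compound 2 and compound 4.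

The compounds shown leave open how a morpholine or a 4,4-difluoropiperidine would read on the sulfonyl sulfur, which would show how far the result holds for simpler nitrogen-bearing rings. They also leave open whether the oxygen of the six-membered ring in compound 4 matters, a question that an all-carbon cyclohexane ring in its place would address.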